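Methoxy for fluoro, second position on the phenyl arm

The source may hold more compounds than are shown below. What is called first, only, known or untested is meant among the compounds shown, and "the series" means these compounds.

compound 1 `COc1ccc2nc(C)cc(NCc3cccc(F)c3)c2c1`: 14700 nM
compound 2 `COc1ccc2nc(C)cc(NCc3ccccc3F)c2c1`: 17000 nM
compound 3 `COc1cccc(CNc2cc(C)nc3ccc(OC)cc23)c1`: 12500 nM

All three were run in a functional assay on MCF-10A cells (Homo sapiens) for antiproliferative activity, with a stated time of 48 h; on this read-out lower numbers stand for an effect already at smaller amounts and higher numbers for an effect only at larger amounts of compound. The cores of compound 1 and compound 2 differ by 2-fluorophenyl in place of 3-fluorophenyl on a saturated chain carbon bound to a nitrogen on an aromatic ring, and the step of a 1.2-fold higher number from compound 1 to compound 2 (0.06 log units; within the scatter) stays within the scatter. On the core of compound 1, the change methoxy in place of fluoro on an aromatic carbon gave a 1.2-fold lower number from compound 1 to compound 3 (0.07 log units; within the scatter), again within the scatter. Compound 4 `COc1ccc2nc(C)cc(NCc3ccccc3OC)c2c1` carries the same kind of change on the core of compound 2, (methoxy in place of fluoro on an aromatic carbon); the place differs, the entering methoxy standing ortho to a large group here, meta to a large group in compound 3. Within the data shown here, with only one prior example, the step from compound 2 to compound 4 is expected as a 1.2-fold lower number from compound 2 to compound 4 (0.07 log units; within the scatter), matching the earlier step from compound 1 to compound 3, which was a 1.2-fold lower number from compound 1 to compound 3 (0.07 log units; within the scatter). Compound 4 is therefore estimated at 14500 nM, spanning 7000 nM to 30000 nM.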

Compound 4, half-maximal effective concentration: 29500 nM
The estimate for compound 4 lay 2.0-fold (0.31 log units) below the measured number; low and high end bracket the measured number.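

In this assay, methoxy in place of fluoro on an aromatic carbon gave a 1.7-fold higher number from compound 2 to compound 4 (0.24 log units; within the scatter). Set beside the earlier step, the result does not separate the two cores: the same change on two cores in this assay, a 1.2-fold lower number (0.07 log units; within the scatter) from compound 1 to compound 3 and a 1.7-fold higher number (0.24 log units; within the scatter) from compound 2 to compound 4, 2.0-fold (0.31 log units) apart, within the scatter of two such steps. This gives no sign that the core of compound 1 and the core of compound 2 respond differently to the change, but it does not show that the two steps are equal, and core and place cannot be told apart, as the two examples differ in both.

Still open, as far as these compounds go, is how an amine or a carboxylic acid on the phenyl arm would compare with fluoro and methoxy. Also open, from the compounds shown here alone, is whether the change reads the same with a longer chain to that arm.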